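Aryl replacement from compound 3 to compound 4

This account rests on a few compounds, and the source may have more. Where it says the series, first, only, none or still open, it means among the compounds named here.

Among the compounds with values here, in a functional assay on KB cells (Homo sapiens) for antiproliferative activity, read by sulforhodamine B assay, with a stated time of 3 days (a lower number here means that less compound is needed, a higher number that more compound is needed for the effect), compound 3 `CCC1=C(O)c2c(oc(-c3ccc(O)c(O)c3)cc2=O)C(CC)(CC)C1=O` gives 10 uM, the lowest of the numbers so far. Compound 2 `CCC1=C(O)c2c(oc(-c3ccc(OC)c(Cl)c3)cc2=O)C(CC)(CC)C1=O` gives 24.9 uM. Compound 1 `CCC1=C(O)c2c(oc(-c3ccc(SC)cc3)cc2=O)C(CC)(CC)C1=O` gives > 52.1 uM, which is a limit and not a number.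

Compound 4 `CCC1=C(O)c2c(oc(-c3cc(C)c(O)c(C)c3)cc2=O)C(CC)(CC)C1=O` differs from compound 3 as follows: 4-hydroxy-3,5-dimethylphenyl in place of 3,4-dihydroxyphenyl on an aromatic carbon. Two measured replacements of the same aryl group bear on this change: a 2.5-fold lower number from compound 2 to compound 3 (0.40 log units; beyond the scatter) and an at least 5.2-fold lower number from compound 1 to compound 3 (0.71 log units; beyond the scatter). Both are modest, and both favour the 3,4-dihydroxyphenyl of compound 3. Leaving that group is therefore expected to give a modestly higher number, estimated as a 1.8-fold higher number from compound 3 to compound 4 (0.26 log units; within the scatter). Compound 4 is expected at 18 uM, with an estimated range of 7 uM to 45 uM.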

Compound 4, concentration for half-maximal effect: 18.3 uM
For compound 4 the middle estimate is 1.0-fold (0.01 log units) below the measured one; the measured number falls inside the stated range.
By their numbers in this assay, from the lowest: compounds 3, 4 and 2 (each within the scatter of the next, the first and the last beyond it). At a limit, above all of these: compound 1.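

In this assay, 4-hydroxy-3,5-dimethylphenyl on the carbon next to the ring oxygen cannot be separated from 3,4-dihydroxyphenyl (a 1.8-fold higher number from compound 3 to compound 4 (0.26 log units; within the scatter)) or from 3-chloro-4-methoxyphenyl (a 1.4-fold lower number from compound 2 to compound 4 (0.13 log units; within the scatter)). Two hydroxyl groups on this aryl group are therefore not required for a number in this range. Within the data shown here, the one step beyond the scatter (an at least 2.8-fold lower number from compound 1 to compound 4 (0.45 log units; beyond the scatter)) rests on a limit, not a number: the limit of > 52.1 uM in this assay, at which 1 of the 4 values shown sits.

Open, going by these compounds, is whether an amine or a carboxylic acid on this aryl group would give a number beyond the scatter of compound 3.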